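A few compounds are considered here, and "the series" means these few. Any claim that something is new, unique, unknown or untested is made for them only; others in the source may bear on it.

Measured compounds:

- compound 1, `Cc1ccnc(-c2cc3n(n2)CCN(C(=O)c2ccccc2)C3)c1`: 451 nM
- compound 2, `O=C(c1ccccc1)N1CCn2nc(-c3ccc(F)cn3)cc2C1`: 164 nM

In a functional assay on HEK293 cells for negative allosteric modulation of metabotropic glutamate receptor 5 (Homo sapiens), read by calcium flux, with a stated time of 20 min (on this read-out lower numbers stand for stronger inhibition and higher numbers for weaker inhibition), compound 1 gives 451 nM and compound 2 gives 164 nM. For the measured compounds named here, of these two numbers compound 2 holds the lower one, its only neighbour being compound 1, and the single step between them, a 2.8-fold lower number from compound 1 to compound 2 (0.44 log units; beyond the scatter), concerns the pyridine end of the molecule, where the fluorine and methyl substituents were swapped.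

Compound 3, `Cc1cc(F)cc(C(=O)N2CCn3nc(-c4ccc(F)cn4)cc3C2)c1`, is not yet measured in this assay. It differs from compound 2 at the other end: 3-fluoro-5-methylphenyl in place of phenyl on a carbonyl carbon. Going by the values given here, no measured step touches this carbonyl-bearing ring, so the one step available gives no direct guide to the size or direction of this change; it only shows that ring substitution elsewhere can move the number by a modest amount.

With nothing bearing on the benzoyl side, the expected number for compound 3 in this assay is close to that of compound 2, with a wide range allowing a modest change in either direction, and the estimated step is a 1.5-fold lower number from compound 2 to compound 3 (0.17 log units; within the scatter). The estimate for compound 3 is 110 nM, between 30 nM and 400 nM.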

Compound 3, half-maximal inhibitory concentration: 197 nM
Estimate against measurement, compound 3: 1.8-fold (0.25 log units) below; the measured number falls inside the stated range.
By their numbers in this assay, from the lowest: compounds 2 and 3 (each within the scatter of the next); then compound 1.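

Putting 3-fluoro-5-methylphenyl in place of phenyl on the carbonyl carbon gives a 1.2-fold higher number from compound 2 to compound 3 (0.08 log units; within the scatter) in this assay, so compound 2 and compound 3 cannot be told apart on this read-out. For the compounds shown here, this is the first measured information about this end of the molecule: here, a ring of 8 heavy atoms carrying both fluorine and methyl gives a number indistinguishable from that of the plain phenyl ring of 6 heavy atoms, with the 5-fluoropyridin-2-yl group kept the same in both compounds. Nothing measured here offers a reason for this result.

The compounds shown carry fluorine and methyl on this ring only as a pair, so what either group does alone stays open, as does whether the same swap would behave alike alongside the 4-methylpyridin-2-yl group of compound 1. Also open, going by these compounds, is whether very different groups on this ring, such as an amine or a carboxylic acid, or a cyclohexyl ring in place of the aromatic one, would leave the number similarly undisturbed.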